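Fluoro for hydroxy on a quiet lipoxygenase series

The source may report more compounds than this note shows. Statements on the series, on what has been measured and on what is new or still open speak of the compounds shown alone.

Three compounds share one core and were tested in an assay on blood for inhibition of Polyunsaturated fatty acid 5-lipoxygenase (Homo sapiens), tested at 10 uM; a lower number here means a weaker effect, a higher number a stronger effect of the compound at the concentration tested. Compound 1 `O=C1OC(c2ccc(OCc3ccccc3)cc2)C(c2ccc(O)cc2)=C1O` gives 0%. Compound 2 `O=C1OC(c2ccc(OCc3ccccc3)cc2)C(c2ccc(F)cc2)=C1O` gives 0%. The change from compound 1 to compound 2 is fluoro in place of hydroxy on an aromatic carbon and it produced no change at the digits printed from compound 1 to compound 2 (within the scatter). Compound 3 `O=C1OC(c2cc(O)cc(O)c2)C(c2ccc(O)cc2)=C1O` gives 0%; how its core differs from that of compound 1 is not broken down here, and its value lies level with those of compound 1 and compound 2 within the scatter.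

Compound 4 `O=C1OC(c2cc(O)cc(O)c2)C(c2ccc(F)cc2)=C1O` has not yet been measured in this assay. It differs from compound 3 by fluoro in place of hydroxy on an aromatic carbon, the same change, at the same kind of place, that turned compound 1 into compound 2.

Because no change at the digits printed from compound 1 to compound 2 (within the scatter) showed no change within the scatter, and because compound 3 gives 0%, the step of no change at the digits printed from compound 3 to compound 4 (within the scatter) is expected to be flat as well. For compound 4 the expected activity in this assay is 0%, with a range from -5% to 10%.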

Compound 4, a percentage reported as activity, at one concentration (the size of the read-out at that concentration, not a potency): 0%
For compound 4 middle estimate and measured number coincide at the digits printed; the range from low to high includes it.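

In this assay, fluoro in place of hydroxy on an aromatic carbon, here 4-hydroxyphenyl to 4-fluorophenyl, gave no change at the digits printed from compound 3 to compound 4 (within the scatter). Set beside the earlier step, the change reads the same on both cores: the same change on two cores in this assay, no change at the digits printed (within the scatter) from compound 1 to compound 2 and no change at the digits printed (within the scatter) from compound 3 to compound 4, 0 percentage points apart, within the scatter of two such steps This does not show that the change is neutral in any wider sense or that it would transfer to a core with a detectable effect, since all four compounds print the same value and both steps join compounds with no read-out to lose, so the agreement is only between two flat steps.

The compounds shown leave open whether any other group at this place, such as an amine, a methoxy group or a carboxylic acid, would give a read-out in this assay. On these data alone, it also remains open how fluoro and hydroxy would compare on a core that shows a measurable effect at the concentration tested.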